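A swap from 4-methoxyphenyl to 2-methoxyphenyl

A few compounds are considered here, and "the series" means these few. Any claim that something is new, unique, unknown or untested is made for them only; others in the source may bear on it.

In a functional assay on THP-1 cells (Homo sapiens) for inhibition, read by sulforhodamine B assay, with a stated time of 48 h, tested at 50 uM (a lower number here means less inhibition of growth, a higher number more inhibition of growth at the concentration tested), compound 3 (`COc1ccc(/C=C/C(=O)/C=C/c2ccc(OCc3cn(CCCCCOc4cc(=O)oc5ccccc45)nn3)c(OC)c2)cc1`) gives 39% of inhibition. This lies within the scatter of both relatives measured so far: compound 1 (`COc1cccc(/C=C/C(=O)/C=C/c2ccc(OCc3cn(CCCCCOc4cc(=O)oc5ccccc45)nn3)c(OC)c2)c1`) gives 37% and compound 2 (`COc1cc(/C=C/C(=O)/C=C/c2cccs2)ccc1OCc1cn(CCCCCOc2cc(=O)oc3ccccc23)nn1`) gives 34% in the same test.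

Compound 4 (`COc1ccccc1/C=C/C(=O)/C=C/c1ccc(OCc2cn(CCCCCOc3cc(=O)oc4ccccc34)nn2)c(OC)c1`) has not yet been measured. It carries 2-methoxyphenyl in place of 4-methoxyphenyl on a double-bonded chain carbon bound to a double-bonded chain carbon.

Three measured steps at this same place bear on the change. The swap from 3-methoxyphenyl to 4-methoxyphenyl gave a number 2 percentage points higher from compound 1 to compound 3 (within the scatter) and is the most similar. The two steps involving thiophen-2-yl gave a number 3 percentage points lower from compound 1 to compound 2 (within the scatter) and a number 5 percentage points higher from compound 2 to compound 3 (within the scatter) in turn. Going by the values given here, all three stayed within the scatter, although no compound with 2-methoxyphenyl has yet been tested.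

No shift beyond the scatter is therefore expected, and the estimated step is a number 2 percentage points lower from compound 3 to compound 4 (within the scatter) in this assay once measured. The estimated value for compound 4 is 37% (range 26% to 48%).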

Compound 4, percent growth inhibition at one concentration: 37%
Estimate against measurement, compound 4: no gap at the digits printed; the measured number falls inside the stated range.
By their numbers in this assay, from the lowest: compounds 2, 1, 4 and 3 (each within the scatter of the next).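

In this assay the 2-methoxyphenyl group joins the 3-methoxyphenyl and 4-methoxyphenyl groups at this place, so all three placements of the methoxy group on the phenyl ring can now be compared. Changing 4-methoxyphenyl to 2-methoxyphenyl gives a number 2 percentage points lower from compound 3 to compound 4 (within the scatter) and changing 3-methoxyphenyl to 2-methoxyphenyl gives no change at the digits printed from compound 1 to compound 4 (within the scatter) while the step from thiophen-2-yl to 2-methoxyphenyl gives a number 3 percentage points higher from compound 2 to compound 4 (within the scatter) so none of the new comparisons separates these groups in this test. Nothing available explains why these swaps leave the number within the scatter.

Still open, as far as these compounds go, is whether a 4-aminophenyl or 4-carboxyphenyl group at this place would move the number beyond the scatter. Also open, from the compounds shown here alone, is whether a longer chain in the part shared by these compounds would do so.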